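Cytotoxicity notes on the benzoxaborole amide series

The compounds below may be only part of what the source reports. "The series", "measured", "known", "first", "only" and "open" are said of these compounds alone.

Compound 1 `O=C(CCc1cccc2c1B(O)OC2)Nc1ccc(Cl)cc1`, compound 2 `CC(C)(C)OC(=O)Nc1ccc(NC(=O)CCc2cccc3c2B(O)OC3)cc1` and compound 3 `CC(C)c1cccc(NC(=O)CCc2cccc3c2B(O)OC3)c1` share one core and were read in an ADME assay on WI-38 cells (Homo sapiens) for cytotoxicity, read by MTT assay, with a stated time of 72 h; on this read-out higher numbers stand for weaker inhibition and lower numbers for stronger inhibition. Compound 1 reaches only the assay limit, > 100000 nM. Compound 2 likewise reaches only the limit, > 100000 nM. The step that the two limits leave unreadable from compound 1 to compound 2 is therefore unreadable because of the limit of > 100000 nM in this assay, at which 2 of the 3 values shown sit. For the measured compounds named here, compound 3 gives 22000 nM, the single numeric value in the set. Compound 4 `CC(=O)c1cccc(-c2cccc(NC(=O)CCc3cccc4c3B(O)OC4)c2)c1` is not yet measured; it carries 3-acetylphenyl in place of isopropyl on an aromatic carbon. Going by the values given here, no measured step bears on this change, so the expected step is a 1.4-fold higher number from compound 3 to compound 4 (0.13 log units; within the scatter), with the size uncertain in either direction. Compound 4 is estimated at 30000 nM, between 8000 nM and 100000 nM.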

Compound 4, half-maximal inhibitory concentration: 2200 nM
Compound 4: middle estimate off by 14-fold (1.13 log units), on the high side; measured number outside the range, below it.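

this assay now holds a readable step, a 10-fold lower number from compound 3 to compound 4 (1.00 log units; beyond the scatter), with 3-acetylphenyl in place of isopropyl on an aromatic carbon, meta to a large group. This is the first sign in the series that a change at this position can move the cytotoxicity number, as the only earlier step cannot be read: the limit of > 100000 nM in this assay, at which 2 of the 4 values shown sit.

Open, from the compounds shown here alone, is whether the lower number goes with the added six-membered aromatic ring or with the acetyl group. A plain phenyl, or a phenyl carrying an amine or a carboxylic acid in place of the acetyl, would separate the two.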